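The source may hold more compounds than are shown below. What is called first, only, known or untested is meant among the compounds shown, and "the series" means these compounds.

Compound 1 `CCOC(=O)c1ccc(-c2nn(Cc3ccc(F)cc3)c3ccccc23)cc1`: in a functional assay on cells (Platelet, Homo sapiens) for inhibition (on this read-out higher numbers stand for weaker inhibition and lower numbers for stronger inhibition), compound 1 gives > 10000 nM, which is a limit of the assay and not a number.
Compound 2 `CCOC(=O)c1ccc(-c2nn(Cc3ccc(OC)cc3)c3ccccc23)cc1`: in this assay compound 2 gives > 10000 nM, again a limit of the assay.
Compound 3 `CCOC(=O)c1ccc(-c2nn(Cc3cccnc3)c3ccccc23)cc1`: in this assay compound 3 gives > 10000 nM, also a limit of the assay.

All three compounds share one core and differ only in the group carried on the aromatic nitrogen. Compound 3 stands at the limit, as do the two others, so no ranking among them is possible; the three values sit together at the limit of > 10000 nM in this assay, at which 3 of the 3 values shown sit. The steps between them, a step that the two limits leave unreadable from compound 1 to compound 2, a step that the two limits leave unreadable from compound 1 to compound 3 and a step that the two limits leave unreadable from compound 2 to compound 3, cannot be read in size or direction, as both of their ends are limits. Compound 4 `CCOC(=O)c1ccc(-c2nn(-c3ccco3)c3ccccc23)cc1` changes compound 3 in one place: furan-2-yl in place of (pyridin-3-yl)methyl on an aromatic nitrogen. Within the data shown here, none of the measured steps offers a readable size, so no direction can be taken from them; what they do show is that every variation of this group so far has stayed at the limit. Compound 4 is expected to stay at or near that limit as well, with an estimated step that the limit leaves unreadable from compound 3 to compound 4 that lies within the scatter. The estimate for compound 4 in this assay is 15000 nM, in a range from 5000 nM to 50000 nM.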

Compound 4, half-maximal inhibitory concentration: > 10000 nM
Compound 4 gave a limit, no number; the forecaster's own chance of this, stated with the estimate: 80%; the middle value is on the limit's open side.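

Compound 4 also gives only a limit of the assay, so the steps linking it to compound 1, compound 2 and compound 3 cannot be read in size or direction, as all four compounds sit at the same limit: the limit of > 10000 nM in this assay, at which 4 of the 4 values shown sit.

The compounds shown leave open which group on the aromatic nitrogen, if any, would give a measurable value in this assay.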